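This account rests on a few compounds, and the source may have more. Where it says the series, first, only, none or still open, it means among the compounds named here.

Measured in a functional assay on K562 cells (Homo sapiens) for inhibition, read by trypan blue exclusion, with a stated time of 72 h; on this read-out higher numbers stand for weaker inhibition and lower numbers for stronger inhibition:
compound 1 `COC(=O)Cn1c(=O)c(S(=O)(=O)c2ccc(F)cc2F)cc2cnc(Nc3ccc4[nH]ccc4c3)nc21`: 5000 nM
compound 2 `Cn1c(=O)c(S(=O)(=O)c2ccc(F)cc2)cc2cnc(Nc3ccc4occc4c3)nc21`: 5000 nM
compound 3 `COc1ccc(Nc2ncc3cc(S(=O)(=O)c4ccc(C)cc4)c(=O)n(C)c3n2)cc1`: 75000 nM

On these numbers, compound 1 gives 5000 nM and stands level with compound 2 at 5000 nM. Together they hold the lowest number of the three. Compound 3 gives 75000 nM. Its gap to both of the others lies well beyond the scatter.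

The next compound, compound 4 `CCCn1c(=O)c(S(=O)(=O)c2ccc(F)cc2F)cc2cnc(Nc3ccc4[nH]ccc4c3)nc21`, keeps the core of compound 1 but has ethyl in place of methoxycarbonyl on a saturated chain carbon bound to an aromatic nitrogen.

Among the measured compounds shown here, no measured pair isolates this change, so the data give no direct size for it. Compound 2 has no methoxycarbonyl and still gives 5000 nM, although it differs from compound 1 in other places too. Compound 3 also lacks that group and gives 75000 nM, so the comparison is only weak support. In this assay, no step beyond the scatter is expected in either direction.

The estimated change is a 1.3-fold lower number from compound 1 to compound 4 (0.10 log units; within the scatter). For compound 4, the expected value is 4000 nM, within an estimated range of 1200 nM to 15000 nM.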

Compound 4, half-maximal inhibitory concentration: 1000 nM
The estimate for compound 4 lay 4.0-fold (0.60 log units) above the measured number, outside the stated range (below it).
By their numbers in this assay, from the lowest: compound 4; then compounds 1 and 2 (each within the scatter of the next); then compound 3.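

Among the compounds shown here, compound 4 gives the first direct reading at this position: in this assay, ethyl in place of methoxycarbonyl on a saturated chain carbon bound to an aromatic nitrogen brings a 5.0-fold lower number from compound 1 to compound 4 (0.70 log units; beyond the scatter). For the compounds shown here, the methoxycarbonyl is therefore not required for inhibition in this pair, and the position responds to this change by a modest step beyond the scatter, which no earlier pair could show. Nothing in the data shown accounts for the step.

This single pair cannot say whether an amine, a carboxylic acid or a longer chain at the same place would give a lower or a higher number. It also leaves open whether the same change would give a similar step on the cores of compound 2 and compound 3.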